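Acylguanidine series: piperidinyl in place of isopropylsulfanyl

This account rests on a few compounds, and the source may have more. Where it says the series, first, only, none or still open, it means among the compounds named here.

Measured so far in a functional assay for inhibition of sodium/hydrogen exchanger (Oryctolagus cuniculus); a higher number here means a weaker inhibitor, a lower number a stronger inhibitor:
- compound 1, `CCc1cc(Br)c(S(C)(=O)=O)cc1C(=O)N=C(N)N`: 41 nM
- compound 2, `Cc1cc(SC(C)C)c(S(C)(=O)=O)cc1C(=O)N=C(N)N`: 12 nM

Compound 2 stands at the lower of the two numbers in this assay; its gap to compound 1 lies beyond the usual scatter, so compound 2 is the stronger inhibitor of the pair on the present data. For the measured compounds named here, no step between the measured compounds is known that would isolate a single change, and compound 1 and compound 2 differ in more than one place, so their values are simply read as they stand.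

Compound 3, `Cc1cc(N2CCCCC2)c(S(C)(=O)=O)cc1C(=O)N=C(N)N`, has not yet been measured. The change from compound 2 is piperidin-1-yl in place of isopropylsulfanyl on an aromatic carbon. Nothing in the measured pair covers an exchange of this kind at this position. A step of modest size, most likely toward a higher number, is expected for a 1.8-fold higher number from compound 2 to compound 3 (0.26 log units; within the scatter), with wide uncertainty. Compound 3 is estimated at 22 nM, within a range of 7 nM to 70 nM.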

Compound 3, half-maximal inhibitory concentration: 21 nM
Compound 3: the middle estimate sits 1.0-fold (0.02 log units) above what was measured; the range from low to high includes it.
By their numbers in this assay, from the lowest: compounds 2, 3 and 1 (each within the scatter of the next, the first and the last beyond it).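

In this assay, for the compounds shown here, the exchange of isopropylsulfanyl for piperidin-1-yl, on the aromatic carbon ortho to the methylsulfonyl group, gives a 1.8-fold higher number from compound 2 to compound 3 (0.24 log units; within the scatter) and is the first step that isolates a single place. At this carbon, an open sulfanyl group and a six-membered non-aromatic ring therefore read alike within the scatter, so this position accepts more than one kind of group in the compounds shown. No measured property on either group bears on this result.

Going by these compounds, whether a smaller ring such as pyrrolidin-1-yl, a morpholin-4-yl ring or an open-chain dimethylamino group reads alike at this carbon remains open. Going by these compounds alone, the ethyl and bromo groups of compound 1 also remain unseparated, as that compound differs from compound 2 in more than one place and gives no single step.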